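Replacement of the amide-side aryl in the cyclopropane diamide series

The source may report more compounds than this note shows. Statements on the series, on what has been measured and on what is new or still open speak of the compounds shown alone.

Among the measured compounds shown here, compound 2 `CN(C)C(=O)c1cc2cnc(Nc3ccc(NC(=O)C4(C(=O)Nc5ccc(Cl)c(C(F)(F)F)c5)CC4)cc3)nc2n1C1CCCC1` gives -11.2% in a functional assay on SiHa cells (Homo sapiens) for inhibition, read by CCK-8 assay, with a stated time of 72 h, tested at 1 uM (on this read-out higher numbers stand for more inhibition of growth at the one concentration tested and lower numbers for less inhibition of growth), the lowest of the three numbers measured so far. Compound 1 `CN(C)C(=O)c1cc2cnc(Nc3ccc(NC(=O)C4(C(=O)Nc5ccc(F)cc5)CC4)cc3F)nc2n1C1CCCC1` gives 6.6% and compound 3 `CN(C)C(=O)c1cc2cnc(Nc3ccc(NC(=O)C4(C(=O)Nc5ccc(O)cc5)CC4)cc3)nc2n1C1CCCC1` gives 69.5% in this assay. For the measured compounds named here, the one step that touches the same amide-type nitrogen is a number 80.7 percentage points higher from compound 2 to compound 3 (beyond the scatter), a large gain. Compound 4 `CN(C)C(=O)c1cc2cnc(Nc3ccc(NC(=O)C4(C(=O)Nc5cccc(F)c5)CC4)cc3)nc2n1C1CCCC1` differs from compound 2 by 3-fluorophenyl in place of 4-chloro-3-(trifluoromethyl)phenyl on an amide-type nitrogen. Going by the values given here, no step with 3-fluorophenyl is measured; the nearest comparison is compound 1, which carries a fluorophenyl at that position and stays low in this assay. A step of a number 23.2 percentage points higher from compound 2 to compound 4 (beyond the scatter) is therefore expected, a modest rise rather than the large gain seen with 4-hydroxyphenyl. For compound 4 the estimate is 12% in this assay, within -8% to 35%.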

Compound 4, percent growth inhibition at one concentration: 29.7%
For compound 4 the middle estimate is 17.7 percentage points below the measured one; the range from low to high includes it.
By their numbers in this assay, from the lowest: compound 2; then compound 1; then compound 4; then compound 3.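

In this assay the step of a number 40.9 percentage points higher from compound 2 to compound 4 (beyond the scatter) shows that a large gain at this amide-type nitrogen does not require 4-hydroxyphenyl: 3-fluorophenyl, with no hydrogen-bond donors or acceptors, also gives one. The step of a number 39.8 percentage points lower from compound 3 to compound 4 (beyond the scatter) nevertheless keeps 4-hydroxyphenyl well ahead of 3-fluorophenyl, so the replacement recovers only part of that gain. The compounds shown leave open whether a phenyl ring bearing an amine or a carboxylic acid in place of the hydroxyl would match compound 3. No evidence bears on why these steps arise.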